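The source may hold more compounds than are shown below. What is called first, only, known or untested is meant among the compounds shown, and "the series" means these compounds.

In a functional assay on RD cells (Homo sapiens) for inhibition, read by luminescence and ATP content, with a stated time of 72 h (a higher number here means that more compound is tolerated, a lower number that less compound is tolerated), compound 1 `CCOC(=O)c1cnc2ccc(-c3cccc(N)c3)cc2c1` gives > 7400 nM, which is a limit of the assay and not a number. Compound 2 `CCCCc1ccc(-c2ccc3ncc(C(=O)OCC)cc3c2)cc1` gives > 7400 nM, which is also only a limit. Compound 3 `CCOC(=O)c1cnc2ccc(-c3ccc(N)cc3)cc2c1` differs from compound 2 by amino in place of butyl on an aromatic carbon, para to a large group. Within the data shown here, no step has been measured, and compound 2 shares (the limit of > 7400 nM in this assay, at which 2 of the 2 values shown sit), so no change beyond the usual scatter is expected in this assay. The estimated step that the limit leaves unreadable from compound 2 to compound 3 is therefore expected to be small. For compound 3 the estimated value is 9000 nM, with an expected range from 4000 nM to 20000 nM.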

Compound 3, half-maximal cytotoxic concentration: > 7400 nM
Compound 3 ended at the assay's limit; the forecaster's own chance of this, stated with the estimate: 85%; the middle value is on the limit's open side.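

Among these compounds, no step between compound 1, compound 2 and compound 3 can be read in this assay, since all three stop at a limit of the assay: the limit of > 7400 nM in this assay, at which 3 of the 3 values shown sit. On these data alone, the concentration at which any of them turns toxic to these cells, and whether swapping these groups changes it, stays open.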